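Furan-2-yl in place of pyridin-3-yl on a shared core

This account rests on a few compounds, and the source may have more. Where it says the series, first, only, none or still open, it means among the compounds named here.

compound 1, `Clc1ccc(-c2cc(-c3ccsc3)nc(-c3ccco3)c2)o1`: 8.2%
compound 2, `Cc1cccc(-c2cc(-c3ccc(Cl)o3)cc(-c3ccsc3)n2)c1`: 7.5%
compound 3, `Clc1ccc(-c2cc(-c3cccnc3)nc(-c3cccs3)c2)o1`: 25.8%

In an assay on isolated protein for inhibition of DNA topoisomerase 1 (Homo sapiens), tested at 100 uM (on this read-out lower numbers stand for a weaker effect and higher numbers for a stronger effect at the one concentration tested), compound 3 stands highest of the three numbers, beyond the scatter above both compound 1 and compound 2. Compound 4, `Clc1ccc(-c2cc(-c3ccco3)nc(-c3cccs3)c2)o1`, differs from compound 3 in one place: furan-2-yl in place of pyridin-3-yl on an aromatic carbon. Among the measured compounds shown here, the only measured step, a number 0.7 percentage points lower from compound 1 to compound 2 (within the scatter), exchanges a different group and lies within the scatter, so it does not bear on this change. For the measured compounds named here, compound 1, which carries furan-2-yl at the same place, gives a value well below that of compound 3, though no step between those two is given. Compound 4 is therefore expected to come in lower than compound 3, by a number 13.8 percentage points lower from compound 3 to compound 4 (beyond the scatter) in this assay, with an estimate of 12% and a range from 3% to 28%.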

Compound 4, a percentage reported as inhibition, at one concentration (the size of the read-out at that concentration, not a potency): 16%
Beside the measured number, compound 4's estimate is 4 percentage points below it; the range from low to high includes it.
By their numbers in this assay, from the lowest: compounds 2, 1, 4 and 3 (each within the scatter of the next, the first and the last beyond it).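

In this assay, furan-2-yl in place of pyridin-3-yl next to the ring nitrogen gives a number 9.8 percentage points lower from compound 3 to compound 4 (within the scatter), so this exchange of a six-membered for a five-membered aromatic ring is not resolved at this position. The exchange of thiophen-3-yl for thiophen-2-yl on an aromatic carbon gives a number 7.8 percentage points higher from compound 1 to compound 4 (within the scatter), and it is not resolved either.

As far as these compounds go, whether an amine or a carboxylic acid at this place would move the number beyond the scatter stays open. No measurement bearing on the cause of these numbers is at hand.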